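Replacing the Sulfonyl Substituent of Compound 2

The source may report more compounds than this note shows. Statements on the series, on what has been measured and on what is new or still open speak of the compounds shown alone.

Measured in a functional assay on HeLa cells (Homo sapiens) for antiproliferative activity, read by MTT assay, with a stated time of 24 h; on this read-out lower numbers stand for stronger inhibition and higher numbers for weaker inhibition:
- compound 1 `O=S(=O)(c1ccc(Br)cc1)n1c(-c2cn(-c3ccccc3)nc2-c2ccc(F)cc2)nc2ccccc21` gives 2040 nM
- compound 2 `Cc1ccc(C)c(S(=O)(=O)n2c(-c3cn(-c4ccccc4)nc3-c3ccc(C(F)(F)F)cc3)nc3ccccc32)c1` gives 210 nM

Of these two, compound 2 has the lower number, and the gap to compound 1 lies beyond the scatter. Compound 3 `O=S(=O)(c1ccc(Br)cc1)n1c(-c2cn(-c3ccccc3)nc2-c2ccc(C(F)(F)F)cc2)nc2ccccc21` has not yet been measured. It differs from compound 2 by one change, (4-bromophenyl in place of 2,5-dimethylphenyl on a sulfonyl sulfur), with 4-bromophenyl in place of 2,5-dimethylphenyl on a sulfonyl sulfur. Going by the values given here, no measured pair isolates this change. Compound 1 also carries 4-bromophenyl on a sulfonyl sulfur and gives 2040 nM, but it differs from compound 2 in more than one place. A moderate rise in the number is therefore expected, somewhat beyond the scatter, and the estimated size is a 3.0-fold higher number from compound 2 to compound 3 (0.47 log units; beyond the scatter). In this assay, the estimate for compound 3 is 620 nM, with an expected range from 180 nM to 2100 nM.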

Compound 3, half-maximal inhibitory concentration: 1860 nM
Beside the measured number, compound 3's estimate is 3.0-fold (0.48 log units) below it; the range from low to high includes it.
By their numbers in this assay, from the lowest: compound 2; then compounds 3 and 1 (each within the scatter of the next).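

In this assay, the exchange on the sulfonyl sulfur now stands as a single change, 4-bromophenyl in place of 2,5-dimethylphenyl (an 8.9-fold higher number from compound 2 to compound 3 (0.95 log units; beyond the scatter)), so this position clearly shifts the read-out while the trifluoromethyl group stays fixed. With 4-bromophenyl held on the sulfonyl sulfur, trifluoromethyl in place of fluoro on an aromatic carbon gives a step that lies within the scatter (a 1.1-fold lower number from compound 1 to compound 3 (0.04 log units; within the scatter)). Nothing available explains why the sulfonyl substituent changes the number.

Here 2,5-dimethylphenyl appears only together with trifluoromethyl, so whether its lower number holds alongside fluoro remains open. Also open, as far as these compounds go, is how an amine or a carboxylic acid on the aromatic ring of the sulfonyl substituent, or a plain alkyl chain in place of that ring, would read in this assay.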